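The compounds below may be only part of what the source reports. "The series", "measured", "known", "first", "only" and "open" are said of these compounds alone.

Compound 1 `CCNc1cc(-c2ccc(NC(=O)Nc3cccc(Cl)c3)cc2F)ccn1` and compound 2 `CCNc1cc(-c2ccc(NC(=O)Nc3ccc(C(F)(F)F)cc3)cc2F)ccn1` share one core, while compound 3 `O=C(Nc1cccc(Cl)c1)Nc1ccc(-c2ccnc(NCC3CC3)c2)c(C(F)(F)F)c1` and compound 4 `O=C(Nc1ccc(C(F)(F)F)cc1)Nc1ccc(-c2ccnc(NCC3CC3)c2)c(C(F)(F)F)c1` are built on another; the difference between the two cores is not broken down here. In an assay on isolated protein for inhibition of serine/threonine-protein kinase PLK1 (Homo sapiens), read by radiometric assay and 33P incorporation, with a stated time of 40 min, tested at 20 uM, in the presence of a further agent that is not named here (a higher number here means more inhibition at the concentration tested (going by the name of the read-out), a lower number less inhibition), compound 1 gives 72.7% and compound 2 gives 55.8%. Between them the change is 4-(trifluoromethyl)phenyl in place of 3-chlorophenyl on an amide-type nitrogen, and it brought a number 16.9 percentage points lower from compound 1 to compound 2 (beyond the scatter). In this assay compound 3 gives 63.8%, which lies within the usual scatter of both other measured compounds. Compound 4 carries the same change as that first pair, (4-(trifluoromethyl)phenyl in place of 3-chlorophenyl on an amide-type nitrogen), made at an identical place. Because the earlier step was a number 16.9 percentage points lower from compound 1 to compound 2 (beyond the scatter), a step of similar size is expected for compound 4, a number 16.8 percentage points lower from compound 3 to compound 4 (beyond the scatter). Compound 4 is therefore estimated at 47%, with a likely range from 32% to 62%.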

Compound 4, a percentage reported as inhibition, at one concentration (the size of the read-out at that concentration, not a potency): 53.4%
The estimate for compound 4 lay 6.4 percentage points below the measured number; the measured number falls inside the stated range.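

In this assay, putting 4-(trifluoromethyl)phenyl in place of 3-chlorophenyl on an amide-type nitrogen gave a number 10.4 percentage points lower from compound 3 to compound 4 (beyond the scatter), the same direction as on the first core. The two steps can be set side by side: the same change on two cores in this assay, a number 16.9 percentage points lower (beyond the scatter) from compound 1 to compound 2 and a number 10.4 percentage points lower (beyond the scatter) from compound 3 to compound 4, 6.5 percentage points apart, within the scatter of two such steps. Among these compounds, this shows that the change carried over between these two cores at the one concentration tested, but it rests on only two pairs and does not show why the number drops or how the change would behave on any other core.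

The compounds shown leave open what a cyclohexyl group or a phenyl ring bearing a carboxylic acid would do on that nitrogen. They also leave open whether the step would hold with a longer chain on the amine of the core.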